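The source may hold more compounds than are shown below. What is called first, only, known or untested is meant among the compounds shown, and "the series" means these compounds.

Measured so far:
- compound 1 `CCO[C@H]1C[C@@H](c2coc3ccc(Br)cc3c2=O)N(c2ccccc2)O1`: 21500 nM
- compound 2 `COC(=O)[C@@]1(C)C[C@@H](c2coc3ccc(F)cc3c2=O)N(c2ccccc2)O1`: 20300 nM

Both compounds were tested in a functional assay on A549 cells (Homo sapiens) for inhibition, read by sulforhodamine B assay, with a stated time of 48 h; on this read-out lower numbers stand for stronger inhibition and higher numbers for weaker inhibition. Compound 1 gives 21500 nM, and compound 2 gives 20300 nM. The two numbers sit within the usual scatter of each other, so compound 2 cannot be set apart from compound 1 on these data; both are weak inhibitors on this scale.

The next compound, compound 3 `COC(=O)[C@@]1(C)C[C@@H](c2coc3ccc(C)cc3c2=O)N(c2ccccc2)O1`, keeps the whole of compound 2 except for one change on the aromatic ring of the shared core: methyl in place of fluoro on an aromatic carbon. Within the data shown here, no pair of measured compounds differs in exactly one place, so there is no measured step of this kind to lean on. Among the measured compounds shown here, the exchange swaps one small group for another of the same size, with no change in donors, acceptors or charge, and nothing among the measured compounds points to a large shift in either direction. The expectation is therefore a step of a 1.0-fold lower number from compound 2 to compound 3 (0.01 log units; within the scatter), within the scatter. On that basis compound 3 is estimated at 20000 nM, with a range from 8000 nM to 50000 nM.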

Compound 3, half-maximal inhibitory concentration: 700 nM
Compound 3: the middle estimate sits 29-fold (1.46 log units) above what was measured; the measured number lies below the stated range.
By their numbers in this assay, from the lowest: compound 3; then compounds 2 and 1 (each within the scatter of the next).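

In this assay, placing methyl instead of fluoro on this aromatic carbon, which is meta to a fused ring and para to a fused ring, gives a step well beyond the scatter (a 29-fold lower number from compound 2 to compound 3 (1.46 log units; beyond the scatter)). Compounds 1 and 2 differ in more than one place, so their similar numbers could not show that this position matters; this single exchange shows that, with the rest of compound 2 held fixed, the choice of group here can move the number by a large amount, even though fluoro and methyl match in every count available: one heavy atom each, no ring, no hydrogen-bond donors or acceptors, and no net charge. No measurement available here accounts for the difference between the two groups.

From the compounds shown here alone, this is a single pair, so it remains open whether methyl would have a similar effect on the core of compound 1. Going by these compounds, it is also open how an ethyl group, a methoxy group or an amine on the same aromatic carbon would compare with methyl in compound 3.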